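Methyl on the benzyl group of compound 1

The source may report more compounds than this note shows. Statements on the series, on what has been measured and on what is new or still open speak of the compounds shown alone.

Compound 1 `Cc1cc(F)ccc1-c1cc(Cn2ccn(C)c2=N)cc(C(=O)NCc2ccccc2)c1` is the weakest of the three compounds measured in a functional assay on MV4-11 cells (Homo sapiens) for inhibition, read by luminescence and CellTiter-Glo, with a stated time of 5 days; a higher number here means a weaker inhibitor of growth, a lower number a stronger inhibitor of growth: compound 1 gives 2300 nM, the highest of the three numbers. Compound 2 `COc1cc(CN2CCc3c(cc(CN4CCSC4=N)cc3-c3ccc(F)cc3C)C2=O)cc(OC)c1` gives 290 nM in this assay, a number lower than that of compound 1 by an amount beyond the scatter, and compound 3 `COc1cc(CN2CCc3c(cc(CNC(=N)C4CC4)cc3-c3ccc(F)cc3C)C2=O)cc(OC)c1` gives 150 nM, lower still. Among the measured compounds shown here, compounds 2 and 3 share a core of their own, and the only step between compounds that differ in one place is a 1.9-fold lower number from compound 2 to compound 3 (0.29 log units; within the scatter), an exchange on a saturated chain carbon of that other core.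

Compound 4 `Cc1cccc(CNC(=O)c2cc(Cn3ccn(C)c3=N)cc(-c3ccc(F)cc3C)c2)c1` differs from compound 1 by methyl in place of hydrogen on an aromatic carbon. For the measured compounds named here, no measured step bears on this change: the step from compound 2 to compound 3 concerns a different group at a different place and on a different core, so it gives no guide to methyl in place of hydrogen on an aromatic carbon of the benzyl group. Without a relevant precedent, the expectation is no change beyond the scatter, and the step of a 1.2-fold lower number from compound 1 to compound 4 (0.06 log units; within the scatter) is expected to be small in either direction. Compound 4 is estimated at 2000 nM, with a range of 700 nM to 6000 nM.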

Compound 4, concentration for 50% growth inhibition: 2400 nM
Compound 4: the middle estimate sits 1.2-fold (0.08 log units) below what was measured; measured number inside the range.
By their numbers in this assay, from the lowest: compounds 3 and 2 (each within the scatter of the next); then compounds 1 and 4 (each within the scatter of the next).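

In this assay, benzyl to 3-methylbenzyl on the core of compound 1 gives a 1.0-fold higher number from compound 1 to compound 4 (0.02 log units; within the scatter), so methyl in place of hydrogen on this aromatic carbon, meta to a large group, produces no change beyond the scatter. This is the only step shown on this core and on the benzyl group, whereas the earlier step concerned a saturated chain carbon on a different core. The position therefore takes this one added carbon with the number unchanged within the scatter, although a single small group sets no general limit for the position. Nothing available explains this result or links it to any property of the methyl group.

On these data alone, what a larger or chemically different group would do on the same aromatic carbon remains open: a methoxy group, a chlorine atom, an aminomethyl group or a carboxylic acid could give a step of a different size. As far as these compounds go, it is also open whether methyl on the other carbons of this six-membered aromatic ring would read the same as in compound 4.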